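The compounds below may be only part of what the source reports. "The series", "measured", "known", "first", "only" and "open" are said of these compounds alone.

Notes on the series. In an assay for inhibition of prolyl hydroxylase EGLN3 (Homo sapiens), read by TR-FRET, with stated times of 30 min and 40 min (a higher number here means a weaker inhibitor, a lower number a stronger inhibitor), compound 1, `O=C(CCc1ccccc1)Nc1cnccc1C(=O)O`, gives 31600 nM. Compound 2, `CCCCNc1cnccc1C(=O)O`, carries a butyl chain on the ring nitrogen in place of the amide-linked chain of compound 1. In this assay compound 2 gives only a limit, > 50100 nM, and no number. Where compound 2 stands is therefore known only as the limit of > 50100 nM in this assay, at which 1 of the 2 values shown sits; nothing more exact can be said of it from the data shown, and no step between the two measured compounds can be stated.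

Compound 3, `NCCCNc1cnccc1C(=O)O`, is the next one to be measured. It differs from compound 2 by amino in place of methyl on a saturated chain carbon, three bonds along the chain from a nitrogen on an aromatic ring: the change reads butyl to 3-aminopropyl. With compound 2 sitting at a limit, any step in this assay from compound 2 to compound 3 can only be read against that limit; the expectation is for a modest step, if any, toward a stronger inhibitor, and a good chance that compound 3 again returns a limit rather than a number. As an estimate, compound 3 is expected to give 45000 nM, within 15000 nM to 100000 nM, which corresponds to an expected step of an at least 1.1-fold lower number from compound 2 to compound 3 (0.04 log units; that floor lies within the scatter).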

Compound 3, half-maximal inhibitory concentration: > 50100 nM
Compound 3: only a limit was reported; the forecaster's own chance of this, stated with the estimate: 55%; middle value at least 1.1-fold (0.04 log units) from the limit.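

In this assay compound 3 gives only a limit, > 50100 nM. No step from compound 2 to compound 3 can be read, since both stand at a limit: the limit of > 50100 nM in this assay, at which 2 of the 3 values shown sit.

The compounds shown leave open whether amino in place of methyl changes inhibition at all, and where compound 2 and compound 3 actually stand.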